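Moving the amide arm in a shared phenoxyphenyl ester series

The source may hold more compounds than are shown below. What is called first, only, known or untested is meant among the compounds shown, and "the series" means these compounds.

Compound 1 `C/C=C/C(=O)Nc1ccc(Cn2nc(-c3ccc(Oc4ccccc4)cc3)cc2C(=O)O)cc1` gives > 60000 nM in a functional assay on Z-138 cells (Homo sapiens) for inhibition, read by luminescence and CellTiter-Glo, with a stated time of 72 h; a lower number here means a stronger inhibitor, a higher number a weaker inhibitor.
Compound 2 `C=CC(=O)Nc1ccc(Cn2nc(-c3ccc(Oc4ccccc4)cc3)cc2C(=O)OCC)cc1` gives 12500 nM in this assay.
Compound 3 `C/C=C/C(=O)Nc1ccc(Cn2nc(-c3ccc(Oc4ccccc4)cc3)cc2C(=O)OCC)cc1` gives > 60000 nM in this assay.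

The value of compound 3 is a limit of the assay, not a number. Its neighbour compound 1 also sits at a limit. Only compound 2 returns a number, and the two readable comparisons both end in compound 3: a step that the two limits leave unreadable from compound 1 to compound 3 cannot be sized, whereas an at least 4.8-fold higher number from compound 2 to compound 3 (0.68 log units; beyond the scatter) shows that vinyl on the carbonyl carbon gives the lower number (the limit of > 60000 nM in this assay, at which 2 of the 3 values shown sit).

Compound 4 `C=CC(=O)Nc1cccc(Cn2nc(-c3ccc(Oc4ccccc4)cc3)cc2C(=O)OCC)c1` is not yet measured. It differs from compound 3 in one piece: 3-((vinylcarbonyl)amino)phenyl in place of 4-(((prop-1-en-1-yl)carbonyl)amino)phenyl on a saturated chain carbon bound to an aromatic nitrogen. Two things change together: vinyl returns on the carbonyl carbon, and the amide arm moves from the 4-position to the 3-position of the phenyl. For the measured compounds named here, the first change is covered by the step between compound 2 and compound 3 and points to a lower number; the second has no measured counterpart here, so its effect is unknown.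

The expected step is therefore an at least 4.0-fold lower number from compound 3 to compound 4 (0.60 log units; beyond the scatter), a drop of at least modest size. Compound 4 is estimated at 15000 nM, with a range from 4000 nM to 60000 nM.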

Compound 4, half-maximal inhibitory concentration: 7800 nM
The estimate for compound 4 lay 1.9-fold (0.28 log units) above the measured number; the measured number falls inside the stated range.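

For the compounds shown here, with vinyl on the carbonyl carbon in both compounds, 3-((vinylcarbonyl)amino)phenyl in place of 4-((vinylcarbonyl)amino)phenyl gives a 1.6-fold lower number from compound 2 to compound 4 (0.20 log units; within the scatter), so the two placements of the amide arm cannot be told apart in this assay, a comparison the earlier compounds did not offer. The other step, an at least 7.6-fold lower number from compound 3 to compound 4 (0.88 log units; beyond the scatter), starts from a limit of the assay and carries both changes at once, and since the placement alone stays within the scatter, it follows the return of vinyl in place of prop-1-en-1-yl. Among the four compounds, the two with vinyl, compound 2 and compound 4, return numbers, while the two with prop-1-en-1-yl, compound 1 and compound 3, stay at a limit: the limit of > 60000 nM in this assay, at which 2 of the 4 values shown sit.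

The compounds shown leave open whether a saturated propanoyl group on the amide nitrogen would return a number like those of compound 2 and compound 4, which would show whether the vinyl double bond itself matters. They also leave open how a methyl ester or a longer chain on the ester oxygen would read with the arm of compound 4.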